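Swapping a Large Side Chain for Hydroxy on a Nucleoside

The source may report more compounds than this note shows. Statements on the series, on what has been measured and on what is new or still open speak of the compounds shown alone.

Of the compounds shown here, two have been tested in an ADME assay on L1210/0 cells (Mus musculus) for cytotoxicity, with a stated time of 48 h; a lower number here means a stronger inhibitor, a higher number a weaker inhibitor. Compound 1, `Nc1ncnc2c1ncn2C1CC(O)C(/C=N/O)O1`, gives 17400 nM. Compound 2, `O=C(CI)NCc1cn([C@H]2C[C@H](O)[C@@H](CO)O2)c(=O)[nH]c1=O`, gives 107000 nM, the higher of the two numbers, so compound 2 is the weaker inhibitor of the pair, and the gap between compound 2 and compound 1 is beyond the usual scatter of repeated measurements.

Compound 3, `O=c1[nH]c(=O)n([C@H]2C[C@H](O)[C@@H](CO)O2)cc1O`, has not yet been measured. It differs from compound 2 in a single place: hydroxy in place of (((iodomethyl)carbonyl)amino)methyl on an aromatic carbon. The sugar part and the shared core stay the same; only the group on that aromatic carbon is exchanged, a group of 6 heavy atoms giving way to a single oxygen.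

Within the data shown here, no measured pair in this set shows what such an exchange does, so the direction of the step rests on expectation alone. Because compound 2 gives 107000 nM, a number that leaves room to fall, the estimate for compound 3 is a modestly lower number, a step of a 2.7-fold lower number from compound 2 to compound 3 (0.43 log units; beyond the scatter). Compound 3 is therefore expected to give about 40000 nM, in a range from 6000 nM to 250000 nM.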

Compound 3, half-maximal inhibitory concentration: > 200000 nM
Compound 3: a limit, no number; the forecaster's own chance of this, stated with the estimate: 10%; middle value at least 5.0-fold (0.69 log units) from the limit.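

Among these compounds, this is the only exchange at this aromatic carbon that can be read in this assay, and putting hydroxy in place of (((iodomethyl)carbonyl)amino)methyl gives an at least 1.8-fold higher number from compound 2 to compound 3 (0.27 log units; that floor lies within the scatter). Trading the side chain of 6 heavy atoms for a single oxygen therefore brought no lower number, which neither compound 1 nor compound 2 could show on its own, since they differ from each other in more than one place. The true size of the step stays unknown, and its floor cannot separate the two compounds beyond the scatter, because the reading for compound 3 is a limit and not a number: the limit of > 200000 nM in this assay, at which 1 of the 3 values shown sits.

Still open, from the compounds shown here alone, is which part of the side chain, if any, matters at this position, since only these two groups on this carbon can be compared. A plain aminomethyl group, or the same chain with chlorine in place of iodine, could separate the iodomethyl end from the rest of the chain, and a compound of that kind with a number inside the range of the assay could give the step a real size.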